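A Methyl Step Repeated on a Core with a Higher Number

The source may report more compounds than this note shows. Statements on the series, on what has been measured and on what is new or still open speak of the compounds shown alone.

Of the compounds shown here, three have been measured in a functional assay on RPMI18226 cells (Homo sapiens) for antiproliferative activity, read by sulforhodamine B assay, with a stated time of 48 h, tested at 10 uM; on this read-out lower numbers stand for less inhibition and higher numbers for more inhibition at the one concentration tested (going by the name of the read-out). Compound 1 `O=C(Nc1ccccc1)c1c(-c2ccc(Cl)cc2)cc(-c2ccccc2)nc1N1CCCCC1` gives 13%. Compound 2 `Cc1ccc(NC(=O)c2c(-c3ccc(Cl)cc3)cc(-c3ccccc3)nc2N2CCCCC2)cc1` gives 24%. Compound 3 `O=C(Nc1ccccc1)c1c(-c2ccc(Cl)cc2)cc(-c2ccccc2)nc1Nc1ccc(Cl)cc1` gives 53%, the highest of the three numbers, and its steps to the other two lie beyond the scatter.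

Two structural changes connect these compounds. The first, (methyl in place of hydrogen on an aromatic carbon), brings a number 11 percentage points higher from compound 1 to compound 2 (beyond the scatter). Among the measured compounds shown here, the second, ((4-chlorophenyl)amino in place of piperidin-1-yl on an aromatic carbon), brings a number 40 percentage points higher from compound 1 to compound 3 (beyond the scatter), so the two cores differ in the group attached to the ring that carries the nitrogen, and the core of compound 3 is the one with the higher number.

Compound 4 `Cc1ccc(NC(=O)c2c(-c3ccc(Cl)cc3)cc(-c3ccccc3)nc2Nc2ccc(Cl)cc2)cc1` has not yet been measured. It carries the core of compound 3 together with the change (methyl in place of hydrogen on an aromatic carbon). The place of this change is described in the same words as the place of the change from compound 1 to compound 2, so it is the same change made on a different core.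

For the measured compounds named here, since the same change once gave a number 11 percentage points higher from compound 1 to compound 2 (beyond the scatter), a step of similar size is expected here, estimated as a number 9 percentage points higher from compound 3 to compound 4 (within the scatter), although only one earlier instance supports this and it rests on one pair alone. Compound 4 is therefore estimated to give 62% in this assay, with a range expected from 45% to 78%.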

Compound 4, a percentage reported as inhibition, at one concentration (the size of the read-out at that concentration, not a potency): 58%
Estimate against measurement, compound 4: 4 percentage points above; low and high end bracket the measured number.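

On the core of compound 3, the methyl change gives a number 5 percentage points higher from compound 3 to compound 4 (within the scatter) in this assay, and it reads the same as the earlier methyl step within the scatter: the same change on two cores in this assay, a number 11 percentage points higher (beyond the scatter) from compound 1 to compound 2 and a number 5 percentage points higher (within the scatter) from compound 3 to compound 4, 6 percentage points apart, within the scatter of two such steps. The exchange of piperidin-1-yl for (4-chlorophenyl)amino also carries over when the methyl is present, giving a number 34 percentage points higher from compound 2 to compound 4 (beyond the scatter), and this step likewise agrees with its earlier counterpart: the same change on two cores in this assay, a number 40 percentage points higher (beyond the scatter) from compound 1 to compound 3 and a number 34 percentage points higher (beyond the scatter) from compound 2 to compound 4, 6 percentage points apart, within the scatter of two such steps. Across these four compounds, the two changes therefore combine without a detectable departure from one core to the other, but this does not show that the methyl makes a distinguishable difference on the core of compound 3, where its step stays within the scatter, and each comparison rests on only two pairs at a single concentration.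

The compounds shown leave open how a longer chain such as ethyl, or a methoxy group or a chlorine atom, would read at the place of the methyl. They also leave open how another amine, such as morpholin-4-yl or benzylamino, would read in place of piperidin-1-yl or (4-chlorophenyl)amino on either form of the anilide.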